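Iodoacetamide on the Aniline Nitrogen: Expected Aortic Response

The source may hold more compounds than are shown below. What is called first, only, known or untested is meant among the compounds shown, and "the series" means these compounds.

Compound 1 `S=C=Nc1ccc(CC2=NCCN2)cc1I`: 28%
Compound 2 `Nc1ccc(CC2=NCCN2)cc1`: 9%
Compound 3 `Cc1ccc(CC2=NCCN2)cc1`: 5%

In an ADME assay on the whole organism (thoracic aorta) with Rattus norvegicus as the target (a lower number here means a smaller maximal response, a higher number a larger maximal response), compound 2 gives 9%, the second highest of the three numbers. Its nearest neighbour is compound 3, which gives 5%; the step of a number 4 percentage points lower from compound 2 to compound 3 (within the scatter) lies within the scatter. Furthest away is compound 1, which gives 28%, a gap beyond the scatter; compound 1, however, differs from compound 2 in two places, so no single step connects the two.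

Compound 4 `O=C(CI)Nc1ccc(CC2=NCCN2)cc1` differs from compound 2 as follows: (iodomethyl)carbonyl in place of hydrogen on a nitrogen on an aromatic ring. Within the data shown here, no measured step touches the nitrogen on the aromatic ring in this way. Among the measured compounds shown here, the one step that bears on the same position of the shared core, from amino to methyl, was within the scatter, and the only higher value, that of compound 1, comes with two changes at once. A modest upward step is therefore expected, a number 7 percentage points higher from compound 2 to compound 4 (within the scatter), with wide uncertainty because compound 1 gives 28% while compound 3 gives 5%.

For compound 4 the estimate in this assay is 16%, with a range from 5% to 30%.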

Compound 4, largest response reached (Emax), in percent of the reference or control that the assay uses: 13%
The estimate for compound 4 lay 3 percentage points above the measured number; the range from low to high includes it.
By their numbers in this assay, from the lowest: compounds 3, 2 and 4 (each within the scatter of the next); then compound 1.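

Putting (iodomethyl)carbonyl in place of hydrogen on a nitrogen on an aromatic ring gives, in this assay, a number 4 percentage points higher from compound 2 to compound 4 (within the scatter), the first measured change made on that nitrogen itself. Replacing methyl on the aromatic carbon with the whole ((iodomethyl)carbonyl)amino group gives a number 8 percentage points higher from compound 3 to compound 4 (within the scatter), so amino, methyl and ((iodomethyl)carbonyl)amino, a group of very different size by its count of heavy atoms, all lie within the scatter of one another at this position of the shared core. Nothing measured here offers an explanation for this result.

An acetyl group on the same nitrogen, carrying no iodine, or a longer acyl chain there would show whether the result holds for other groups at this nitrogen or belongs to the (iodomethyl)carbonyl alone. Also open is which of its two differences from the other compounds goes with the value of compound 1, 28%, since a compound with only one of those changes is not among those shown.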